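Swapping the aryl amide for a dimethyl-isoxazolyl amide

The source may report more compounds than this note shows. Statements on the series, on what has been measured and on what is new or still open speak of the compounds shown alone.

Three compounds share one core and differ only in the group on the amide nitrogen. Compound 1 `COc1ccc2nc(C)cc(OCC(=O)Nc3c(C)cccc3C)c2c1` gives 4.55 in a physicochemical assay for lipophilicity, read by HPLC, in phosphate buffer, measured as chromatographic lipophilicity, at pH 7.4; on this read-out higher numbers stand for higher lipophilicity and lower numbers for lower lipophilicity. Compound 2 `COc1ccc2nc(C)cc(OCC(=O)Nc3cc(C)ccc3OC)c2c1` gives 5.65, and compound 3 `COc1ccc2nc(C)cc(OCC(=O)Nc3ccc(F)cc3)c2c1` gives 4.49. Compound 3 sits at the low end of these numbers: compound 1 lies within the scatter of it, while compound 2 is clearly above, as the step of a number 1.16 log units lower from compound 2 to compound 3 (beyond the scatter) shows; the step of a number 0.06 log units lower from compound 1 to compound 3 (within the scatter) stays within the scatter.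

Compound 4 `COc1ccc2nc(C)cc(OCC(=O)Nc3noc(C)c3C)c2c1` carries the change (4,5-dimethyl-1,2-oxazol-3-yl in place of 4-fluorophenyl on an amide-type nitrogen). Going by the values given here, the two measured steps that exchange the group on the amide nitrogen, a number 0.06 log units lower from compound 1 to compound 3 (within the scatter) and a number 1.16 log units lower from compound 2 to compound 3 (beyond the scatter), both swap one carbon-only six-membered ring for another; neither brings in a five-membered ring with two hetero atoms and two acceptors, so no measured step matches this change directly. With no closer guide, compound 4 is estimated at 3.5, with a range from 2.9 to 4.1. That estimate corresponds to an expected step of a number 0.99 log units lower from compound 3 to compound 4 (beyond the scatter), beyond the scatter.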

Compound 4, distribution coefficient: 3.3
For compound 4 the middle estimate is 0.20 log units above the measured one; the range from low to high includes it.
By their numbers in this assay, from the lowest: compound 4; then compounds 3 and 1 (each within the scatter of the next); then compound 2.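

In this assay, the 4,5-dimethyl-1,2-oxazol-3-yl group on the amide nitrogen gives the lowest number of the four compounds, with a number 1.19 log units lower from compound 3 to compound 4 (beyond the scatter), a number 1.25 log units lower from compound 1 to compound 4 (beyond the scatter) and a number 2.35 log units lower from compound 2 to compound 4 (beyond the scatter). The earlier compounds shown here showed only exchanges among six-membered aromatic rings of carbon only; this step shows that a five-membered aromatic ring with 2 hetero atoms can take the number below all of them, even though 3>4 leaves the heavy-atom count unchanged at 7. Nothing shown here gives a measured reason for the fall.

Going by these compounds alone, with only one such ring, the ring itself and its two methyl groups cannot be told apart. From the compounds shown here alone, how a pyridine ring or an unsubstituted 1,2-oxazol-3-yl group would read at this position stays open.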